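Swapping tert-butyl for 3-fluorocyclobutyl on the shared core

The source may hold more compounds than are shown below. What is called first, only, known or untested is meant among the compounds shown, and "the series" means these compounds.

Compound 1, `CC(C)(C)n1nc(Oc2cc(O)ccn2)c2c(N)ncnc21`: 0.617 h
Compound 2, `Nc1ncnc2c1c(Oc1cccc(C(F)(F)F)c1)nn2[C@H]1C[C@H](O)C1`: 0.367 h
Compound 3, `Cc1cccc(Oc2nn(C(C)(C)C)c3ncnc(N)c23)c1`: 0.0717 h

In an ADME assay on microsomes from liver (Mus musculus) for metabolic stability, read by LC-MS, using NADPH, with a stated time of 10 min, tested at 10 uM (a higher number here means that the compound lasts longer, a lower number that the compound disappears faster), compound 1 shows the highest of the three numbers, though compound 2 sits within the scatter of it; compound 3 lies furthest away, after the step of an 8.6-fold lower number from compound 1 to compound 3 (0.93 log units; beyond the scatter). Compound 4, `Nc1ncnc2c1c(Oc1cc(O)ccn1)nn2[C@H]1C[C@H](F)C1`, differs from compound 1 by 3-fluorocyclobutyl in place of tert-butyl on an aromatic nitrogen. Among the measured compounds shown here, no measured step changes this position alone. Compound 2 carries a related ring on the same nitrogen but also differs elsewhere, so its value only shows that such compounds can give numbers near compound 1. The step to compound 3 concerns another position and does not bear on this change. Compound 4 is therefore expected to stay close to compound 1, with a 1.2-fold lower number from compound 1 to compound 4 (0.09 log units; within the scatter) no larger than the scatter. The estimated value of compound 4 is 0.5 h, within 0.2 h to 1.2 h.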

Compound 4, half-life: 0.267 h
For compound 4 the middle estimate is 1.9-fold (0.27 log units) above the measured one; low and high end bracket the measured number.
By their numbers in this assay, from the lowest: compound 3; then compounds 4, 2 and 1 (each within the scatter of the next, the first and the last beyond it).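

The nitrogen position now has its first measured step: with the rest of the molecule unchanged, 3-fluorocyclobutyl in place of tert-butyl gives a 2.3-fold lower number from compound 1 to compound 4 (0.36 log units; beyond the scatter) in this assay. The group on this aromatic nitrogen therefore affects the number on its own, although the step is modest and smaller than the one seen earlier at the oxygen-linked ring. Nothing available explains why the number falls.

The compounds shown leave open whether the four-membered ring or the fluorine accounts for the step. A plain cyclobutyl on the same nitrogen would separate the two.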